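The compounds below may be only part of what the source reports. "The series", "measured", "known", "first", "only" and "open" are said of these compounds alone.

Compound 1, `Cc1nc(Cl)sc1S(=O)(=O)N1CCC(N2CCC(C)CC2)CC1`, in an ADME assay on HCT-116 cells (Homo sapiens) for cytotoxicity, read by CellTiter-Glo, with a stated time of 72 h (a higher number here means a weaker inhibitor, a lower number a stronger inhibitor), gives > 10000 nM, which is a limit of the assay and not a number.
Compound 2, `Cc1cc(C)c(S(=O)(=O)N2CCC(N3CCC(C(C)C)CC3)CC2)c(C)c1`, in this assay gives > 5000 nM, again a limit.
Compound 3, `C#CCCC(=O)CC1CCN(C2CCN(S(=O)(=O)c3c(C)cc(C)cc3C)CC2)CC1`, in this assay gives > 5000 nM, again a limit.

Compound 1 therefore stands only at a limit, and the two further values shown are limits as well: the limit of > 10000 nM in this assay, at which 1 of the 3 values shown sits, and (the limit of > 5000 nM in this assay, at which 2 of the 3 values shown sit). Among the compounds with values here, the only step among the measured compounds, a step that the two limits leave unreadable from compound 2 to compound 3, is one that the two limits leave unreadable, so its size is not known.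

Compound 4, `CC1CCN(C2CCN(S(=O)(=O)c3cc(Cl)cc(Cl)c3)CC2)CC1`, differs from compound 1 in one place: 3,5-dichlorophenyl in place of 2-chloro-4-methyl-1,3-thiazol-5-yl on a sulfonyl sulfur. Within the data shown here, no measured step touches this change, and none of the three compounds gives a number to move from. The expectation for compound 4 in this assay therefore rests on the limits alone, and compound 4 is expected to stay at a limit, with a step that the limit leaves unreadable from compound 1 to compound 4 expected to be no step beyond the scatter. Compound 4 is thus estimated at 15000 nM, within a range from 5000 nM to 50000 nM.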

Compound 4, half-maximal inhibitory concentration: > 5000 nM
Compound 4: a limit, no number (the forecaster's own chance of this, stated with the estimate: 80%); the middle value does not contradict the limit.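

In this assay compound 4 gives > 5000 nM, which is a limit and not a number. With compound 1 also at a limit, the step from compound 1 to compound 4 cannot be read. The compounds shown leave open how far any change of group shifts the half-maximal inhibitory concentration in this assay.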